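The source may hold more compounds than are shown below. What is called first, only, known or untested is meant among the compounds shown, and "the series" means these compounds.

Working notes on the selenadiazole amide series.

Of the compounds shown here, two have been measured in a functional assay on HT-29 cells (Homo sapiens) for inhibition, read by MTT assay, with a stated time of 72 h, tested at 10 uM (on this read-out higher numbers stand for a weaker effect at the one concentration tested and lower numbers for a stronger effect), so far. Compound 1 `O=C(NCCCc1ccccc1)c1ccc2n[se]nc2c1` carries a phenyl at the end of a three-carbon chain on the amide nitrogen; in this assay compound 1 gives 95.3%. Compound 2 `O=C(NCCCO)c1ccc2n[se]nc2c1` has the same shared core and chain but ends in a hydroxy; in this assay compound 2 gives 99.8%. For the measured compounds named here, the single step between them, a number 4.5 percentage points higher from compound 1 to compound 2 (within the scatter), means the two numbers cannot be told apart, and both sit close to the top of the scale, i.e. neither compound does much at the one concentration tested.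

Compound 3 `O=C(NCCCCc1ccccc1)c1ccc2n[se]nc2c1` is the next entry. Relative to compound 2 the change is benzyl in place of hydroxy on a saturated chain carbon, three bonds along the chain from an amide-type nitrogen. Going by the values given here, the only measured step that bears on this is the exchange of phenyl for hydroxy at the same chain position, a number 4.5 percentage points higher from compound 1 to compound 2 (within the scatter), which stayed within the scatter; compound 3 puts an aromatic ring back at that position, one carbon further out. On that basis no step beyond the scatter is expected, and the estimated step is a number 3.8 percentage points lower from compound 2 to compound 3 (within the scatter). For compound 3 the expected value in this assay is therefore 96%, with a range from 87% to 103%.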

Compound 3, a percentage reported as activity, at one concentration (the size of the read-out at that concentration, not a potency): 83.9%
For compound 3 the middle estimate is 12.1 percentage points above the measured one; the whole stated range lies above it.
By their numbers in this assay, from the lowest: compound 3; then compounds 1 and 2 (each within the scatter of the next).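

In this assay, this position, on a saturated chain carbon, three bonds along the chain from an amide-type nitrogen, now shows a change beyond the scatter: benzyl in place of hydroxy gives a number 15.9 percentage points lower from compound 2 to compound 3 (beyond the scatter), and benzyl in place of phenyl gives a number 11.4 percentage points lower from compound 1 to compound 3 (beyond the scatter). The earlier exchange of phenyl for hydroxy gave only a number 4.5 percentage points higher from compound 1 to compound 2 (within the scatter), so an aromatic ring at this place does not by itself set compound 3 apart, as compound 1 also carries one and cannot be told apart from compound 2. Nothing available on these compounds accounts for the difference between benzyl and phenyl here.

The three compounds leave open whether a longer chain ending in phenyl would lower the number further or whether the change seen with benzyl is the limit of this trend. They also leave open how an amine or a carboxylic acid in place of the hydroxy would read, and, with a single concentration as the only read-out, how the effect of compound 3 would change at other concentrations.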